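Bromo to Trifluoromethyl: What to Expect for Compound 3

The compounds below may be only part of what the source reports. "The series", "measured", "known", "first", "only" and "open" are said of these compounds alone.

Compound 2 `C=CC(=O)Nc1cccc(NC(=O)CSc2nc(Nc3ccc(Br)cc3)c3ccccc3n2)c1` is the lower of the two numbers measured in a functional assay on NCI-H1975 cells (Homo sapiens) for inhibition, read by MTT assay, with a stated time of 72 h (on this read-out lower numbers stand for stronger inhibition and higher numbers for weaker inhibition), where compound 2 gives 6280 nM and compound 1 `C=CC(=O)Nc1cccc(NC(=O)CSc2nc(Nc3cccc(Br)c3)c3ccccc3n2)c1` gives 12100 nM; the step of a 1.9-fold lower number from compound 1 to compound 2 (0.28 log units; within the scatter) separates them. Compound 3 `C=CC(=O)Nc1cccc(NC(=O)CSc2nc(Nc3ccc(C(F)(F)F)cc3)c3ccccc3n2)c1` differs from compound 2 by trifluoromethyl in place of bromo on an aromatic carbon. Within the data shown here, no measured step exchanges one group for another at this position; the single step only moves the bromo. The step from compound 2 to compound 3 is therefore expected to be a 1.0-fold lower number from compound 2 to compound 3 (0.02 log units; within the scatter), and compound 3 is estimated at 6000 nM in this assay, within 2500 nM to 15000 nM.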

Compound 3, half-maximal inhibitory concentration: 12900 nM
Compound 3: middle estimate off by 2.2-fold (0.33 log units), on the low side, and the stated range covers the measured number.
By their numbers in this assay, from the lowest: compounds 2, 1 and 3 (each within the scatter of the next, the first and the last beyond it).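

In this assay, among these compounds, swapping bromo for trifluoromethyl gives the first step beyond the scatter, a 2.1-fold higher number from compound 2 to compound 3 (0.31 log units; beyond the scatter), so this position does respond to the group it carries, if only modestly. Compound 3 and compound 1 cannot be told apart, with a 1.1-fold higher number from compound 1 to compound 3 (0.03 log units; within the scatter), even though they carry different groups at different places on the ring. Nothing available explains why the exchange weakens inhibition. On these data alone, it remains open how an amine, a methoxy group or a carboxylic acid at this position would compare with bromo.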